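The source may hold more compounds than are shown below. What is called first, only, known or untested is meant among the compounds shown, and "the series" means these compounds.

Measured in a functional assay on KBVIN cells (Homo sapiens) for antiproliferative activity, read by sulforhodamine B assay, with a stated time of 3 days; a lower number here means that less compound is needed, a higher number that more compound is needed for the effect:
compound 1 `CCCc1ccc(-c2cc(=O)c3c(o2)C(CC)(CC)C(=O)C(CC)=C3O)cc1`, 12.2 uM
compound 2 `CCOc1ccc(-c2cc(=O)c3c(o2)C(CC)(CC)C(=O)C(CC)=C3O)cc1`, 7.54 uM
compound 3 `CCC1=C(O)c2c(oc(-c3cccc(C(F)(F)F)c3)cc2=O)C(CC)(CC)C1=O`, 5.42 uM

Compound 1 has the highest number of the three. Compound 2 sits nearest to it, and compound 3 stands furthest, its value against that of compound 1 showing a gap beyond the scatter. Compound 4 `CCC1=C(O)c2c(oc(-c3ccccc3F)cc2=O)C(CC)(CC)C1=O` differs from compound 1 in one place: 2-fluorophenyl in place of 4-propylphenyl on an aromatic carbon. For the measured compounds named here, the only measured step that alters the same aryl group, a 1.6-fold lower number from compound 1 to compound 2 (0.21 log units; within the scatter), stayed within the scatter, so a large move is not expected; still, compound 3 with its changed aryl group gives the lowest number seen. A modest lowering is therefore expected for compound 4, a 1.6-fold lower number from compound 1 to compound 4 (0.21 log units; within the scatter). Compound 4 is estimated at 7.5 uM, with a range of 3.5 uM to 15 uM.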

Compound 4, concentration for half-maximal effect: 3.93 uM
Estimate against measurement, compound 4: 1.9-fold (0.28 log units) above; the range from low to high includes it.
By their numbers in this assay, from the lowest: compounds 4, 3, 2 and 1 (each within the scatter of the next, the first and the last beyond it).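

At the aromatic carbon next to the ring oxygen, 2-fluorophenyl, with fewer heavy atoms than 4-propylphenyl, gives a 3.1-fold lower number from compound 1 to compound 4 (0.49 log units; beyond the scatter), so in this assay the propyl chain is not needed to keep this activity. Against the ethoxy analogue the same group gives a 1.9-fold lower number from compound 2 to compound 4 (0.28 log units; within the scatter), which leaves compound 2 and compound 4 not clearly apart. Nothing available explains the change in either step. The compounds shown cannot separate the effect of adding fluorine from that of removing the chain. On these data alone, how an unsubstituted phenyl or an aminophenyl group would compare at this position remains open.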